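The source may report more compounds than this note shows. Statements on the series, on what has been measured and on what is new or still open speak of the compounds shown alone.

Measured compounds in a functional assay on the whole organism (strain Fisher 344) for inhibition, with Rattus norvegicus as the target, read by paw edema, with a stated time of 3.5 h, at a dose of 0.01 mmol/kg by the intraperitoneal route; on this read-out lower numbers stand for less inhibition and higher numbers for more inhibition at the one dose given (going by the name of the read-out):
compound 1 `Cc1ccc2oc(=O)c(C(=O)Nc3ccccc3N)c(O)c2c1` — 60%
compound 2 `NCCNC(=O)c1c(O)c2ccccc2oc1=O` — 59%

In this assay compound 2 gives 59% and compound 1 gives 60%; the two values lie within the scatter of each other, so nothing separates them. Compound 3 `Cc1ccc2oc(=O)c(C(=O)NCCN)c(O)c2c1` is not yet measured. Relative to compound 2 it carries methyl in place of hydrogen on an aromatic carbon. For the measured compounds named here, no step between measured compounds is available for this change; compound 1 carries the same methyl and sits at the same level as compound 2, so no shift beyond the scatter is expected. The expected step of a number 1 percentage points higher from compound 2 to compound 3 (within the scatter) is flat. Compound 3 is estimated at 60%, in the range 46% to 72%.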

Compound 3, a percentage reported as inhibition, in the whole organism at one dose (the size of the read-out at that dose, not a potency): 59%
Compound 3: the middle estimate sits 1 percentage points above what was measured; the range from low to high includes it.
By their numbers in this assay, from the lowest: compounds 2, 3 and 1 (each within the scatter of the next).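

In this assay, methyl in place of hydrogen on the aromatic carbon gives no change at the digits printed from compound 2 to compound 3 (within the scatter) and so leaves the read-out unmoved at this position of the shared core. With the methyl present on both sides, 2-aminoethyl in place of 2-aminophenyl on the amide-type nitrogen gives a number 1 percentage points lower from compound 1 to compound 3 (within the scatter) and does not separate the two groups. Nothing available explains why either change leaves the read-out flat.

Open, as far as these compounds go, is whether methoxy or chloro at this aromatic carbon would hold the same level. Also open, from the compounds shown here alone, is how a longer aminoalkyl chain or a carboxylic acid on the amide-type nitrogen would read out.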